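The source may report more compounds than this note shows. Statements on the series, on what has been measured and on what is new or still open speak of the compounds shown alone.

Compound 2, `Clc1cccc2c1CC2CCCN1CCN(c2cccc3c2OCCO3)CC1`, is the reference point. In a functional assay on the whole organism for antagonist activity, with Rattus norvegicus as the target (on this read-out lower numbers stand for an effect already at smaller amounts and higher numbers for an effect only at larger amounts of compound), compound 2 gives 0.63 mg/kg, the lowest of the two numbers available. Going by the values given here, its only measured neighbour is compound 1, `c1ccc2c(c1)CC2CCCCN1CCN(c2cccc3c2OCCO3)CC1`, which in this assay gives 5 mg/kg; the step of a 7.9-fold lower number from compound 1 to compound 2 (0.90 log units; beyond the scatter) is the one comparison on record.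

Compound 3, `c1ccc2c(c1)CC(CCCN1CCN(c3cccc4c3OCCO4)CC1)C2`, has not yet been measured. The change from compound 2 to compound 3 is a group of 9 heavy atoms (9 carbon; one five-membered non-aromatic ring of carbon only, one six-membered aromatic ring of carbon only) in place of a group of 9 heavy atoms (8 carbon, 1 chlorine; one four-membered non-aromatic ring of carbon only, one six-membered aromatic ring of carbon only), on a saturated chain carbon, three bonds along the chain from an amine nitrogen in a ring. The measured step from compound 1 to compound 2 is the only one that bears on this, and only loosely: it swapped one nine-atom group for another at the same chain position, with the chlorine entering, and the number fell beyond the scatter. Going from compound 2 to compound 3 the chlorine leaves again, which on that single precedent points toward a higher number, while the larger five-membered ring is untested. The expected step is therefore a modest rise, a 3.2-fold higher number from compound 2 to compound 3 (0.50 log units; beyond the scatter), with a wide spread. Compound 3 is estimated to give 2 mg/kg in this assay, likely between 0.6 mg/kg and 6 mg/kg.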

Compound 3, minimum effective dose: 0.63 mg/kg
The estimate for compound 3 lay 3.2-fold (0.50 log units) above the measured number, within the range that was stated.
By their numbers in this assay, from the lowest: compounds 2 and 3 (each within the scatter of the next); then compound 1.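

In this assay, the read-out at this place on the chain does not depend on chlorine: the 2,3-dihydro-1H-inden-2-yl group carries none, and the exchange for the chlorine-bearing group with the four-membered ring gives no change at the digits printed from compound 2 to compound 3 (within the scatter). The two all-carbon groups of equal heavy-atom count, one with a four-membered and one with a five-membered non-aromatic ring, are also separated by a 7.9-fold lower number from compound 1 to compound 3 (0.90 log units; beyond the scatter), so a number beyond the scatter from that of compound 1 is reached both with chlorine and without it, and the earlier step cannot be credited to chlorine alone. Nothing measured here explains why these groups give matching numbers or why the all-carbon pair is separated.

The compounds shown leave open whether a chlorine, fluorine or methoxy group on the 2,3-dihydro-1H-inden-2-yl group would move the number in this assay. They also do not tell how a six-membered non-aromatic ring, as in a tetrahydronaphthalenyl group, or a longer chain carrying the 2,3-dihydro-1H-inden-2-yl group would compare.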